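Swapping a Cyanobenzyl Arm for a Methylbenzyl Arm

A few compounds are considered here, and "the series" means these few. Any claim that something is new, unique, unknown or untested is made for them only; others in the source may bear on it.

Compound 1, `N#Cc1ccc(Cn2cncc2CNc2ccc(C(=O)Nc3cccc([N+](=O)[O-])c3)c(-c3ccccc3)c2)cc1`, reaches only the limit > 10 uM in a functional assay on NIH3T3 cells (Mus musculus); a higher number here means that more compound is needed for the effect, a lower number that less compound is needed.
Compound 2, `N#Cc1ccc(Cn2cncc2CNc2ccc(C(=O)NCc3ccccc3)c(-c3ccccc3)c2)cc1`, reaches only the limit > 10 uM in this assay.
Compound 3, `CSCC[C@H](NC(=O)c1ccc(NCc2cncn2Cc2ccc(C#N)cc2)cc1-c1ccccc1)C(=O)O`, reaches only the limit > 10 uM in this assay.

Compound 3 thus stands at a limit of the assay, not at a number, and the two other compounds stand at the same limit. Every value is a limit. The steps among the measured compounds therefore cannot be sized: a step that the two limits leave unreadable from compound 1 to compound 2, a step that the two limits leave unreadable from compound 1 to compound 3, and a step that the two limits leave unreadable from compound 2 to compound 3. Among the measured compounds shown here, the only evidence is the limit of > 10 uM in this assay, at which 3 of the 3 values shown sit.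

Compound 4, `CSCC[C@H](NC(=O)c1ccc(NCc2cncn2Cc2ccccc2C)cc1-c1ccccc1)C(=O)O`, differs from compound 3 at another part of the molecule than the three measured steps do: 2-methylphenyl in place of 4-cyanophenyl on a saturated chain carbon bound to an aromatic nitrogen. For the measured compounds named here, none of the measured steps touches this part, and none of them could be sized anyway, so they give no guide to the direction or size of the change in this assay. The step expected here is a step that the limit leaves unreadable from compound 3 to compound 4, that is, nothing that could be told apart from the scatter or from the limit. Compound 4 is therefore estimated to give about 25 uM in this assay, somewhere between 5 uM and 150 uM, and most likely it will again be reported only as a limit.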

Compound 4, concentration for half-maximal effect: > 10 uM
Compound 4 was reported as a limit (the forecaster's own chance of this, stated with the estimate: 80%); the middle value is on the limit's open side.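

In this assay compound 4 gives > 10 uM, which is a limit and not a number. Compound 3 also stands at a limit, so the swap of 4-cyanobenzyl for 2-methylbenzyl between compound 3 and compound 4 cannot be sized. The compounds shown leave open what concentration any of them needs for the effect, and whether any of these changes alters it.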